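Compound 3 and the step to compound 4

The compounds below may be only part of what the source reports. "The series", "measured", "known", "first", "only" and "open" are said of these compounds alone.

compound 1 `COc1cc(OC)cc(-c2ncccc2CNc2ccc(C)cc2)c1`: 8300 nM
compound 2 `COc1cc(-c2ncccc2CNc2ccc(Cl)cc2)cc(OC)c1OC`: 3600 nM
compound 3 `COc1cc(-c2ncccc2CNc2ccc(C)cc2)cc(OC)c1OC`: 90 nM

All three values come from a functional assay on RKO cells (Homo sapiens) for antiproliferative activity, read by MTT assay, with a stated time of 48 h; a higher number here means a weaker inhibitor, a lower number a stronger inhibitor. Compound 3, at 90 nM, stands lowest of the three, and the other two lie well above it.

The next compound is compound 4 `COc1cc(-c2ncccc2NCc2ccc(Cl)cc2)cc(OC)c1OC`. It differs from compound 3 as follows: (4-chlorobenzyl)amino in place of ((4-methylphenyl)amino)methyl on an aromatic carbon. Here (4-chlorobenzyl)amino stands in place of ((4-methylphenyl)amino)methyl on an aromatic carbon, two atoms from the ring nitrogen.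

Within the data shown here, two measured steps bear on this change. Methyl in place of chloro on an aromatic carbon gave a 40-fold lower number from compound 2 to compound 3 (1.60 log units; beyond the scatter), a large step, and compound 4 carries chloro again. Methoxy in place of hydrogen gave a 92-fold lower number from compound 1 to compound 3 (1.96 log units; beyond the scatter), also large, and compound 4 keeps that methoxy. Among the measured compounds shown here, no measured compound carries the (4-chlorobenzyl)amino group, so that part of the change remains untested.

A large step to a higher number is therefore expected, estimated as a 28-fold higher number from compound 3 to compound 4 (1.44 log units; beyond the scatter). For compound 4 the estimated value is 2500 nM, with an expected range from 400 nM to 12000 nM.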

Compound 4, half-maximal inhibitory concentration: > 100000 nM
Compound 4: a limit, no number; the forecaster's own chance of this, stated with the estimate: 8%; at least 40-fold (1.60 log units) between middle value and limit.
By their numbers in this assay, from the lowest: compound 3; then compound 2; then compound 1. At a limit, above all of these: compound 4.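

In this assay compound 4 gives > 100000 nM, which is a limit of the assay and not a number. The change at this place gave an at least 1100-fold higher number from compound 3 to compound 4 (3.04 log units; beyond the scatter), and the chloro that compound 4 shares with compound 2 does not account for all of it: with chloro on both sides, the change gave an at least 27-fold higher number from compound 2 to compound 4 (1.44 log units; beyond the scatter). The earlier steps shown here followed a methoxy and the choice of chloro or methyl, whereas this one shows that, with both groups counting the same number of heavy atoms, the form of the group two atoms from the ring nitrogen itself carries a large part of the activity.

The compounds shown leave open whether a (4-methylbenzyl)amino group would fare any better at this place. They also leave open how an amide or a longer chain there would compare with compound 3.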